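The compounds below may be only part of what the source reports. "The series", "measured", "known", "first", "only" and "open" are said of these compounds alone.

Measured compounds and their values:

Compound 1, `C=CC1=C(C(=O)O)C(c2ccc(F)cc2)OC1`: in a functional assay on SW480 cells (Homo sapiens) for cytotoxicity, read by MTT assay, with a stated time of 24 h (a lower number here means a stronger inhibitor, a higher number a weaker inhibitor), compound 1 reaches only a limit, > 100000 nM.
Compound 2, `C=CC1=C(C(=O)NCc2ccc(Cl)cc2)C(c2ccc(F)cc2)OC1`: compound 2 likewise reaches only a limit, > 100000 nM.
Compound 3, `C=CC1=C(C(=O)NC(C)(C)C)C(c2ccc(F)cc2)OC1`: compound 3 too reaches only a limit, > 100000 nM.

Compound 3 therefore stands nowhere readable on the numbers shown: its value is a limit, and the two other values are limits of the same kind. The step to compound 4, `C=CC1=C(C(=O)Nc2ccccc2)C(c2ccc(F)cc2)OC1`, is phenyl in place of tert-butyl on an amide-type nitrogen. Among the compounds with values here, two measured steps bear on it, a step that the two limits leave unreadable from compound 1 to compound 3 and a step that the two limits leave unreadable from compound 2 to compound 3, and neither has a readable size because of the limit of > 100000 nM in this assay, at which 3 of the 3 values shown sit. With all three values at the limit, no direction can be read for a change on the amide-type nitrogen, and a fourth substituent there gives no reason to expect a reading beyond the scatter. The step that the limit leaves unreadable from compound 3 to compound 4 is thus expected to be close to none. For compound 4 the estimate is 150000 nM, within a range from 40000 nM to 500000 nM, most probably again reported only as a limit.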

Compound 4, half-maximal inhibitory concentration: > 100000 nM
Compound 4 gave a limit, no number; the forecaster's own chance of this, stated with the estimate: 80%; the middle value lies beyond the limit too.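

In this assay compound 4 gives > 100000 nM, which is a limit. Within the data shown here, no step from compound 1, compound 2 or compound 3 to compound 4 can be read, because every value ends at the same point: the limit of > 100000 nM in this assay, at which 4 of the 4 values shown sit. The compounds shown leave open which change to the shared core, if any, would give a measurable value in this assay.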